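The source may hold more compounds than are shown below. What is called first, only, known or untested is meant among the compounds shown, and "the series" means these compounds.

Measured compounds:
- Compound 1, `CN(C)C(=O)c1cc2cnc(Nc3ccc(C(=O)NCCCCCCN=C=S)cc3)nc2n1C1CCCC1`: 35.8%
- Compound 2, `CN(C)C(=O)c1cc2cnc(Nc3ccc(NC(=O)CCCCN=C=S)cc3)nc2n1C1CCCC1`: 38.2%

In a functional assay on A549 cells (Homo sapiens) for inhibition, read by CCK-8 assay, with a stated time of 72 h, tested at 1 uM (on this read-out higher numbers stand for a stronger effect at the one concentration tested and lower numbers for a weaker effect), compound 1 gives 35.8% and compound 2 gives 38.2%. Among the measured compounds shown here, compound 2 is one of only two compounds measured, and the step of a number 2.4 percentage points higher from compound 1 to compound 2 (within the scatter) shows that the two sit together. That step swaps the whole tail on an aromatic carbon: a group of 10 heavy atoms (6 carbon, 2 nitrogen, 1 oxygen, 1 sulfur; no ring) in place of a group of 12 heavy atoms (8 carbon, 2 nitrogen, 1 oxygen, 1 sulfur; no ring), and the read-out barely moves.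

Compound 3, `CN(C)C(=O)c1cc2cnc(Nc3ccc(NC(=O)CCCCCCN=C=S)cc3)nc2n1C1CCCC1`, has not yet been measured. It differs from compound 2 by a group of 5 heavy atoms (3 carbon, 1 nitrogen, 1 sulfur; no ring) in place of a group of 3 heavy atoms (1 carbon, 1 nitrogen, 1 sulfur; no ring), on a saturated chain carbon, four bonds along the chain from a carbonyl carbon; that is, the chain to the isothiocyanate grows by two carbons. For the measured compounds named here, the only step that bears on this is a number 2.4 percentage points higher from compound 1 to compound 2 (within the scatter), where a larger change in the same tail left the read-out within the scatter. A chain lengthening alone is therefore expected to bring no step beyond the scatter in this assay. For compound 3 a read-out of 38% is estimated, between 26% and 50%, meaning an expected step of a number 0.2 percentage points lower from compound 2 to compound 3 (within the scatter).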

Compound 3, a percentage reported as inhibition, at one concentration (the size of the read-out at that concentration, not a potency): 43.3%
Compound 3: the middle estimate sits 5.3 percentage points below what was measured, within the range that was stated.
By their numbers in this assay, from the lowest: compounds 1, 2 and 3 (each within the scatter of the next).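

In this assay the group of 5 heavy atoms in place of the group of 3 heavy atoms, on a saturated chain carbon, four bonds along the chain from a carbonyl carbon, brings a number 5.1 percentage points higher from compound 2 to compound 3 (within the scatter) and so isolates the chain length, which the earlier pair could not do because its step changed the tail as a whole. The two tails of equal size and equal atom counts, which differ in the direction of the amide, give a number 7.5 percentage points higher from compound 1 to compound 3 (within the scatter) and so show that turning the amide round at this chain length also leaves the read-out within the scatter. All three compounds therefore stand together in this assay, and no measurement is available here that would explain any difference among them.

From the compounds shown here alone, what stays open is whether a still longer chain, or a short ether chain in its place, would move the read-out beyond the scatter. Going by these compounds, it is equally open whether the isothiocyanate matters at all, a question that an acrylamide or a simple methyl group at the end of the tail would address.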